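The source may report more compounds than this note shows. Statements on the series, on what has been measured and on what is new or still open speak of the compounds shown alone.

Compound 2, `COc1ccc(-n2cc(COc3ccc(/C=C/C(C)=O)cc3OC)nn2)cc1`, gives 21300 nM in a functional assay on HCT-116 cells (Homo sapiens) for antiproliferative activity, read by MTT assay, with a stated time of 48 h; a lower number here means a stronger inhibitor, a higher number a weaker inhibitor. Compound 3, `COc1cc(/C=C/C(C)=O)ccc1OCc1cn(-c2c(Cl)cccc2Cl)nn1`, gives 2000 nM in this assay. Compound 1, `COc1cc(/C=C/C(C)=O)ccc1OCc1cn(-c2ccc(/N=N/c3ccccc3)cc2)nn1`, reaches only a limit in this assay, > 100000 nM.

Among the two plain numbers, compound 2 stands highest; compound 3 lies an 11-fold lower number from compound 2 to compound 3 (1.03 log units; beyond the scatter). The value of compound 1 is a limit, (the limit of > 100000 nM in this assay, at which 1 of the 3 values shown sits), so the step from compound 1 to compound 2 is only bounded: an at least 4.6-fold lower number from compound 1 to compound 2 (0.67 log units; beyond the scatter).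

Compound 4 is `COc1cc(/C=C/C(C)=O)ccc1OCc1cn(-c2ccc(NC(=O)c3ccccc3)cc2)nn1`. It differs from compound 2 in one place: benzamido in place of methoxy on an aromatic carbon. Among the compounds with values here, of the measured steps, only the one from compound 1 to compound 2 bears on this change, since it too exchanges a small methoxy for a larger group carrying a further aromatic ring at the same position, in the opposite direction; that step gave a lower number on going to methoxy. The step from compound 2 to compound 3 changes a different part of the molecule and offers no guide here.

Compound 4 is therefore expected to give a higher number than compound 2, an estimated step of a 2.6-fold higher number from compound 2 to compound 4 (0.41 log units; beyond the scatter), with a real chance that only a limit is reached. The value of compound 4 is estimated at 55000 nM, in a range from 15000 nM to 200000 nM.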

Compound 4, half-maximal inhibitory concentration: > 100000 nM
Compound 4 ended at the assay's limit; the forecaster's own chance of this, stated with the estimate: 35%; at least 1.8-fold (0.25 log units) between middle value and limit.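

Benzamido in place of methoxy gives an at least 4.6-fold higher number from compound 2 to compound 4 (0.67 log units; beyond the scatter), so the loss seen with the large group of compound 1 is not confined to that one group. In this assay, two different large groups carrying a further aromatic ring on this aromatic carbon, para to a large group, now leave compound 1 and compound 4 without a plain number: the limit of > 100000 nM in this assay, at which 2 of the 4 values shown sit. Both values are limits, so the step between compound 1 and compound 4 cannot be read and the two groups cannot be ranked.

The compounds shown leave open whether an amine, a hydroxyl or an ethoxy group on this carbon would still give a plain number. They also leave open whether the loss follows the further aromatic ring or the linking atoms, since a benzyl group or a simple acetamido group is not among them.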